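This account rests on a few compounds, and the source may have more. Where it says the series, first, only, none or still open, it means among the compounds named here.

Compounds measured so far in a functional assay on J774 cells (Mus musculus) for cytotoxicity; on this read-out higher numbers stand for weaker inhibition and lower numbers for stronger inhibition:

- Compound 1, `CCCN(CCC)c1c([N+](=O)[O-])cc(S(=O)(=O)Nc2ccc(Cl)c(Cl)c2)cc1[N+](=O)[O-]`: 7200 nM
- Compound 2, `CCN(CC)c1c([N+](=O)[O-])cc(S(=O)(=O)Nc2ccccc2)cc1[N+](=O)[O-]`: 48000 nM

Compound 2, at 48000 nM, holds the higher of these two numbers. Its gap to compound 1 lies beyond the usual scatter of repeated measurements. The next compound to be tested is compound 3, `CCCCN(CCCC)c1c([N+](=O)[O-])cc(S(=O)(=O)Nc2ccccc2)cc1[N+](=O)[O-]`. It keeps the rest of compound 2 and changes one group: dibutylamino in place of diethylamino on an aromatic carbon, ortho to two nitro groups. For the measured compounds named here, no measured pair isolates a change of this kind, so the data offer little guidance. Compound 1, at 7200 nM, has longer chains on the amine nitrogen than compound 2, but it also carries chloro groups that compound 2 lacks, so it gives only a weak hint. A moderate move toward a lower number and stronger inhibition is expected, a 3.0-fold lower number from compound 2 to compound 3 (0.48 log units; beyond the scatter), although a step within the scatter cannot be excluded. In this assay the estimate for compound 3 is 16000 nM, with an expected range from 5000 nM to 50000 nM.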

Compound 3, half-maximal inhibitory concentration: 12000 nM
Estimate against measurement, compound 3: 1.3-fold (0.12 log units) above; the range from low to high includes it.
By their numbers in this assay, from the lowest: compounds 1 and 3 (each within the scatter of the next); then compound 2.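

In this assay, dibutylamino in place of diethylamino on an aromatic carbon, ortho to two nitro groups, gives a modest step (a 4.0-fold lower number from compound 2 to compound 3 (0.60 log units; beyond the scatter)). For the compounds shown here, this is the first pair that isolates a change at this position, and it shows that the read-out responds to the chains on the amine nitrogen alone, with the rest of compound 2 kept, whereas compound 1 carries longer chains together with chloro groups and could not separate the two changes. No measured evidence accompanies this step, so it stands as an observation only.

With a single matched pair at this position, the compounds shown leave open whether a longer chain such as dihexylamino would continue in the same direction, or whether a cyclic amine such as piperidine or morpholine would behave like the open chains. They also leave open whether the same exchange of diethylamino for dibutylamino would give a similar step in a compound that carries the chloro groups of compound 1.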